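The source may report more compounds than this note shows. Statements on the series, on what has been measured and on what is new or still open speak of the compounds shown alone.

Measured in a functional assay on DU-145 cells (Homo sapiens) for inhibition, read by trypan blue exclusion, with a stated time of 96 h; on this read-out lower numbers stand for stronger inhibition of growth and higher numbers for weaker inhibition of growth:
- compound 1 `O=C(/C(=C\c1ccc(Cl)cc1)S(=O)(=O)c1ccc(Br)cc1)c1ccc(Br)cc1`: 50000 nM
- compound 2 `Cc1ccc(S(=O)(=O)/C(=C/c2ccc(C)s2)C(=O)c2ccc(Br)cc2)cc1`: 25000 nM

Among the measured compounds shown here, only these two numbers are available for the series so far. Compound 2, at 25000 nM, stands within the usual scatter of compound 1, at 50000 nM, so no order can be read between them.

The next compound to be read in this assay is compound 3 `COc1ccccc1/C=C(\C(=O)c1ccc(Br)cc1)S(=O)(=O)c1ccc(C)cc1`. It carries 2-methoxyphenyl in place of 5-methylthiophen-2-yl on a double-bonded chain carbon bound to a double-bonded chain carbon.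

For the measured compounds named here, no two measured compounds differ in one place only, so the data give no direct measure of this exchange. Going by the values given here, the only guide is that compound 1 and compound 2 differ in more than one place, yet compound 1, at 50000 nM, and compound 2, at 25000 nM, lie within the scatter of each other. On that thin basis, no change beyond the scatter is expected in this assay, in either direction. The expected step is a 1.1-fold lower number from compound 2 to compound 3 (0.06 log units; within the scatter). For compound 3 the estimated value is 22000 nM, with an expected range of 7000 nM to 60000 nM.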

Compound 3, concentration for 50% growth inhibition: 1000 nM
For compound 3 the middle estimate is 22-fold (1.34 log units) above the measured one; the measured number lies below the stated range.
By their numbers in this assay, from the lowest: compound 3; then compounds 2 and 1 (each within the scatter of the next).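

In this assay, among the compounds shown here, 2-methoxyphenyl in place of 5-methylthiophen-2-yl on a double-bonded chain carbon bound to a double-bonded chain carbon gives a 25-fold lower number from compound 2 to compound 3 (1.40 log units; beyond the scatter) and so provides the first one-place reading. It shows that the group at this place can move the growth-inhibition read-out well beyond the scatter, which compound 1 and compound 2 could not show, since they differ in more than one place. The two groups match in hydrogen-bond donors, hydrogen-bond acceptors and net charge but differ in heavy atoms and ring type, and nothing available ties the step to any one of these differences.

As far as these compounds go, whether the step belongs to the six-membered carbon ring or to its methoxy group remains open, and plain phenyl, 2-hydroxyphenyl and 2-ethoxyphenyl at this place would bear on that question. Also open, from the compounds shown here alone, is whether the step keeps its size when other parts of compound 3 change, or whether a ring carrying an amine or a carboxylic acid is tolerated here.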